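A few compounds are considered here, and "the series" means these few. Any claim that something is new, unique, unknown or untested is made for them only; others in the source may bear on it.

Compound 2, `CC(=O)OC/C(=C/c1ccc(Cl)cc1)C(=O)c1ccc(Cl)cc1`: 5700 nM
Compound 1, `CC(=O)OC/C(=C/c1ccc(Cl)cc1Cl)C(=O)c1ccccc1`: 22000 nM

Of the compounds shown here, two have been tested in a functional assay on HeLa cells (Homo sapiens) for inhibition, read by sulforhodamine B assay, with a stated time of 48 h; on this read-out higher numbers stand for weaker inhibition of growth and lower numbers for stronger inhibition of growth. Compound 2 gives 5700 nM, and compound 1 gives 22000 nM. Among the measured compounds shown here, compound 2 stands lowest of the two numbers, and its gap to compound 1 is wider than the usual scatter of repeated measurements; since these two compounds differ in more than one place, the values show only that compound 1 inhibits growth less strongly, not which part of the structure accounts for it. Compound 3, `CC(=O)OC/C(=C/c1ccc(Cl)cc1Cl)C(=O)c1ccc(Cl)cc1`, has not yet been tested in this assay. Against compound 2 it carries a single change: chloro in place of hydrogen on an aromatic carbon. This brings one half of compound 3 into line with compound 1, while the other half stays as in compound 2. For the measured compounds named here, no single-change step between measured compounds is available to set the size of this effect. A modest move toward weaker growth inhibition is expected, near the edge of the scatter, as the step of a 1.6-fold higher number from compound 2 to compound 3 (0.20 log units; within the scatter). Compound 3 is therefore estimated at 9000 nM, with a likely range from 3500 nM to 25000 nM.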

Compound 3, concentration for 50% growth inhibition: 19000 nM
Compound 3: middle estimate off by 2.1-fold (0.32 log units), on the low side; the range from low to high includes it.
By their numbers in this assay, from the lowest: compound 2; then compounds 3 and 1 (each within the scatter of the next).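

In this assay, among the compounds shown here, going from 4-chlorophenyl to 2,4-dichlorophenyl gives a 3.3-fold higher number from compound 2 to compound 3 (0.52 log units; beyond the scatter), the first single-change reading: a chloro placed ortho to a large group, on a ring that already carries a chloro, goes with weaker inhibition of growth. This shift lies beyond the usual scatter of repeated measurements. A chloro added to an aromatic carbon of the other aromatic ring gives a 1.2-fold lower number from compound 1 to compound 3 (0.06 log units; within the scatter), so with the 2,4-dichlorophenyl group in place, that second change leaves no mark that can be told apart from the scatter. Nothing available here explains why the chloro at the first position has this effect, and no other data bear on the result.

These compounds leave open whether the loss belongs to chloro itself or would also appear with a smaller fluoro or a methoxy group at the same place. They also leave open how growth inhibition responds when the acetate ester is exchanged for a carboxylic acid, an amine or a longer chain.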